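Aryl replacement on compound 3: expected maximal response

The source may hold more compounds than are shown below. What is called first, only, known or untested is meant among the compounds shown, and "the series" means these compounds.

Three compounds share a core carrying a carboxymethyl group. Compound 1 `O=C(O)Cc1sc(Cc2ccccc2-c2ccccc2)nc1-c1ccc(Cl)cc1` gives 50% in an in vitro functional assay on HEK285-7 cells for antagonist activity at prostaglandin D2 receptor 2 (Homo sapiens), read by BRET and beta-arrestin recruitment (on this read-out lower numbers stand for smaller maximal responses and higher numbers for larger maximal responses), and compound 2 `CCC(c1ccccc1)c1nc(-c2ccc(Cl)cc2)c(CC(=O)O)s1` gives 50%. Compound 3 `O=C(O)Cc1sc(C(c2ccc(F)cc2)c2ccc(F)cc2)nc1-c1ccnc(Cl)c1` gives 80%, the highest of the three numbers; its nearest neighbour is compound 1, lower by a margin beyond the scatter, and compound 2 is equally far below it. Compound 4 `O=C(O)Cc1sc(C(c2ccc(F)cc2)c2ccc(F)cc2)nc1-c1cc(F)cc(F)c1` differs from compound 3 by 3,5-difluorophenyl in place of 2-chloropyridin-4-yl on an aromatic carbon. Going by the values given here, no measured pair in the set isolates this change, so the expectation rests on the spread of the three numbers alone. The step of a number 15 percentage points lower from compound 3 to compound 4 (beyond the scatter) is estimated as a moderate decrease that may still fall within the scatter. For compound 4 the expected value is 65%, within a range of 40% to 90%.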

Compound 4, largest response reached (reported as efficacy), in percent of the reference or control that the assay uses: 80%
The estimate for compound 4 lay 15 percentage points below the measured number; the measured number falls inside the stated range.
By their numbers in this assay, from the lowest: compounds 1 and 2 (each within the scatter of the next); then compounds 3 and 4 (each within the scatter of the next).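

In this assay the read-out shows no change at the digits printed from compound 3 to compound 4 (within the scatter) as 3,5-difluorophenyl replaces 2-chloropyridin-4-yl on this aromatic carbon next to the ring nitrogen. In this pair, the ring hetero atom, the chlorine and the hydrogen-bond acceptor of the leaving group are therefore not required to sustain the maximal response, and a ring of carbon only serves equally well. No evidence on hand explains this outcome.

As far as these compounds go, whether the position tolerates a non-aromatic group such as cyclohexyl, or an aryl ring bearing an amine, remains open.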